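The source may report more compounds than this note shows. Statements on the series, on what has been measured and on what is new or still open speak of the compounds shown alone.

Of the compounds shown here, three have so far been tested in a functional assay on MIA PaCa-2 cells (Homo sapiens) for inhibition, read by MTT assay, with a stated time of 3 days; a lower number here means a stronger inhibitor, a higher number a weaker inhibitor. Compound 1 `CCOC(=O)[C@@H]1CCCN(S(=O)(=O)c2ccc(S(=O)(=O)N3CCCCC3)cc2)C1` gives > 10000 nM, which is a limit of the assay rather than a number. Compound 3 `CCN(CC)S(=O)(=O)c1ccc(S(=O)(=O)N2CCC[C@@H](C(=O)N3CC4(CN(C(=O)OC(C)(C)C)C4)C3)C2)cc1` likewise gives > 10000 nM, again a limit. Compound 2 `CC(C)c1noc(N2CCN(C(=O)[C@@H]3CCCN(S(=O)(=O)c4ccc(S(=O)(=O)C5CCC5)cc4)C3)CC2)n1` also reaches only a limit, at > 10000 nM. Every measured value therefore rests at the limit of > 10000 nM in this assay, at which 3 of the 3 values shown sit, so compound 2 cannot be set apart from the others on the numbers known. Compound 4 `CCNS(=O)(=O)c1ccc(S(=O)(=O)N2CCC[C@@H](C(=O)N3CCN(c4nc(C(C)C)no4)CC3)C2)cc1` differs from compound 2 in one place: ethylamino in place of cyclobutyl on a sulfonyl sulfur. For the measured compounds named here, with all values at the limit there is no measured step by which to size this change, and nothing known points to a gain. The expected step is a number no higher from compound 2 to compound 4 (the limit leaves the size open). Compound 4 is expected at 10000 nM, within 3000 nM to 30000 nM.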

Compound 4, half-maximal inhibitory concentration: > 10000 nM
Compound 4: a limit, no number; the forecaster's own chance of this, stated with the estimate: 85%; the middle value lies on the limit itself.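

Compound 4 gives > 10000 nM in this assay, a limit and not a number, and since compound 2 also stands at a limit, no step can be read between them. The compounds shown leave open which structure, if any, would give a measurable value in this assay.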